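The source may report more compounds than this note shows. Statements on the series, on what has been measured and on what is new or still open speak of the compounds shown alone.

Measured compounds in the series:
compound 1 `CCCC(=O)N1c2ccccc2CCC1C(=O)Nc1ccccc1C(F)(F)F`, > 70000 nM in a functional assay on HCT-15 cells (Homo sapiens) for cytotoxicity, read by sulforhodamine B assay, with a stated time of 72 h; a lower number here means a stronger inhibitor of growth, a higher number a weaker inhibitor of growth;
compound 2 `CCCCCCCCC(=O)N1c2ccccc2CCC1C(=O)Nc1ccccc1C(F)(F)F`, 7700 nM;
compound 3 `O=C(Nc1ccccc1C(F)(F)F)C1CCc2ccccc2N1`, 40400 nM.

The value of compound 1 is a limit of the assay, not a number (the limit of > 70000 nM in this assay, at which 1 of the 3 values shown sits). Among the numbers actually reported, compound 3 stands highest: its nearest measured neighbour, compound 2, sits a 5.2-fold higher number from compound 2 to compound 3 (0.72 log units; beyond the scatter). Compound 4 `CCC(=O)N1c2ccccc2CCC1C(=O)Nc1ccccc1C(F)(F)F` is not yet measured. It differs from compound 3 by propanoyl in place of hydrogen on a nitrogen on an aromatic ring in a ring.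

Among the measured compounds shown here, two measured steps bear on this change, both concerning the same ring nitrogen. Removing the longer octylcarbonyl gives a 5.2-fold higher number from compound 2 to compound 3 (0.72 log units; beyond the scatter), whereas removing the shorter propylcarbonyl gives an at least 1.7-fold lower number from compound 1 to compound 3 (0.23 log units; that floor lies within the scatter), with the floor of that step within the scatter. The short acyl group on compound 1 thus sits at or beyond the limit, and propanoyl on compound 4 is shorter still by one carbon. A number higher than that of compound 3, or a limit, is therefore expected for compound 4; the estimated step is a 1.7-fold higher number from compound 3 to compound 4 (0.24 log units; within the scatter). Compound 4 is estimated at 70000 nM, within 30000 nM to 200000 nM.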

Compound 4, concentration for 50% growth inhibition: > 80000 nM
Compound 4: a limit, no number; the forecaster's own chance of this, stated with the estimate: 55%; middle value at least 1.1-fold (0.05 log units) from the limit.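

In this assay compound 4 gives no number, only a limit of the assay: the limit of > 80000 nM in this assay, at which 1 of the 4 values shown sits.

Propanoyl on this nitrogen on an aromatic ring, in place of hydrogen, gives an at least 1.9-fold higher number from compound 3 to compound 4 (0.29 log units; that floor lies within the scatter), so this short acyl group shows no gain in growth inhibition over the free nitrogen of compound 3, although the size of the loss stays unfixed. Loss of hexyl from the acyl chain gives an at least 10-fold higher number from compound 2 to compound 4 (1.01 log units; beyond the scatter), which extends the chain-length dependence to a second short acyl compound: among the acylated compounds shown, only compound 2 gives a number, while compound 1 and compound 4 both sit at limits, and the step from one of these to the other cannot be read.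

The compounds shown leave open where along the acyl chain growth inhibition first appears, and whether a longer chain than octylcarbonyl on this nitrogen goes further than compound 2. Also open, on these data alone, is whether a chain ending in an amine or a carboxylic acid, or a benzoyl group, would keep the activity of compound 2 on the same core.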